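The source may report more compounds than this note shows. Statements on the series, on what has been measured and on what is new or still open speak of the compounds shown alone.

Compound 1, `Cn1c(-c2ccc(NC(=O)CN3CCCC3)cc2)nc2cc(C(F)(F)F)ccc21`, gives 16000 nM in an ADME assay on MT4 cells (Homo sapiens) for cytotoxicity, read by MTT assay, with a stated time of 96 h; a lower number here means that less compound is tolerated, a higher number that more compound is tolerated. Compound 3, `O=C(CN1CCCC1)Nc1ccc(-c2nc3cc(C(F)(F)F)ccc3[nH]2)cc1`, differs from it in one place, hydrogen in place of methyl on an aromatic nitrogen, and in this assay compound 3 gives 18000 nM. The step is a 1.1-fold higher number from compound 1 to compound 3 (0.05 log units; within the scatter). Compound 2, `C#C[C@@]1(O)[C@H](O)[C@@H](CO)O[C@H]1n1ccc(N)nc1=O`, returns only a limit of the assay, >= 100000 nM. The third value shown is thus (the limit of >= 100000 nM in this assay, at which 1 of the 3 values shown sits). Among the two numbers measured outright, compound 1 has the lowest, with compound 3 close by and within the scatter of it.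

Compound 4, `Cn1c(-c2ccc(NC(=O)CN3CCCCC3)cc2)nc2cc(C(F)(F)F)ccc21`, carries piperidin-1-yl in place of pyrrolidin-1-yl on a saturated chain carbon bound to a carbonyl carbon. Within the data shown here, no measured step touches this part of the molecule; the only step measured, from compound 1 to compound 3, sits elsewhere and is within the scatter. The change from compound 1 to compound 4 is therefore expected to bring a step of no change at the digits printed from compound 1 to compound 4 (within the scatter), no larger than the scatter. Compound 4 is estimated at 16000 nM, with a range from 7000 nM to 40000 nM.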

Compound 4, half-maximal cytotoxic concentration: 9000 nM
For compound 4 the middle estimate is 1.8-fold (0.25 log units) above the measured one; the range from low to high includes it.
By their numbers in this assay, from the lowest: compounds 4, 1 and 3 (each within the scatter of the next). At a limit, above all of these: compound 2.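

The saturated ring on the chain carbon bound to a carbonyl carbon now has a measured step of its own: with piperidin-1-yl in place of pyrrolidin-1-yl, this assay shows a 1.8-fold lower number from compound 1 to compound 4 (0.25 log units; within the scatter). Among these compounds, this position, like the aromatic nitrogen of the earlier step, has so far given no step beyond the scatter, although only this one swap of a five-membered for a six-membered ring has been read here. Nothing given about these compounds bears on this step.

As far as these compounds go, whether a morpholin-4-yl ring, a dimethylamino group or a carboxylic acid at this place would give a step beyond the scatter remains open. Also open, from the compounds shown here alone, is what piperidin-1-yl would give with hydrogen in place of methyl on the aromatic nitrogen.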